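Hydroxy in place of chloro on the shared core

The source may hold more compounds than are shown below. What is called first, only, known or untested is meant among the compounds shown, and "the series" means these compounds.

Measured in a functional assay on SW982 cells (Homo sapiens) for inhibition, read by MTT assay, with a stated time of 72 h; a higher number here means a weaker inhibitor, a lower number a stronger inhibitor:
- compound 1 `COc1cc(OC)c(-c2cc(=O)c3cc(Cl)ccc3o2)cc1OC`: > 150000 nM
- compound 2 `COc1cc(OC)c(OC)cc1/C=C/C(=O)c1cccc([N+](=O)[O-])c1`: 101000 nM

Compound 1 sits at the limit of > 150000 nM in this assay, at which 1 of the 2 values shown sits. That entry is a limit of the assay and not a number. Going by the values given here, compound 2 gives 101000 nM, the only numeric value so far.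

Compound 3 `COc1cc(OC)c(-c2cc(=O)c3cc(O)ccc3o2)cc1OC` keeps the core of compound 1 and carries hydroxy in place of chloro on an aromatic carbon, meta to a fused ring and para to a fused ring (hydroxy in place of chloro on an aromatic carbon). Among the compounds with values here, no measured step covers this change, so the expectation is loose. A small move towards a stronger inhibitor in this assay is expected, though none beyond the scatter is also possible, and another limit may be reported. The expected change is an at least 1.2-fold lower number from compound 1 to compound 3 (0.09 log units; that floor lies within the scatter). For compound 3 the estimate is 120000 nM, with an expected range from 50000 nM to 200000 nM.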

Compound 3, half-maximal inhibitory concentration: > 150000 nM
Compound 3: a limit, no number; the forecaster's own chance of this, stated with the estimate: 40%; middle value at least 1.2-fold (0.09 log units) away from the limit.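

In this assay compound 3 gives > 150000 nM, a limit of the assay and not a number. Compound 1 also stands at a limit, so no step can be read between compound 1 and compound 3: the limit of > 150000 nM in this assay, at which 2 of the 3 values shown sit.

The compounds shown leave open what size of change hydroxy in place of chloro makes on the shared core.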